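Shortening the Ethyl Chain on the Core of Compound 1

The source may hold more compounds than are shown below. What is called first, only, known or untested is meant among the compounds shown, and "the series" means these compounds.

Measured compounds:
Compound 1, `CCc1cc(C)cc2nc(N3CCN(C)CC3)oc12`, gives 6.46 in a functional assay on ileum (strain Hartley) for agonist activity at 5-hydroxytryptamine receptor 3A (Cavia porcellus); a lower number here means a less potent compound, a higher number a more potent compound, by a factor of ten per unit of this negative logarithm.
Compound 2, `CC(C)c1cccc2nc(N3CCN(C)CC3)oc12`, gives only a limit, < 4, in this assay.

Among the measured compounds shown here, compound 1 stands alone as the only real number in this set; the other value shown is a limit, which in the assay is described as the limit of < 4 in this assay, at which 1 of the 2 values shown sits. For the measured compounds named here, compound 2 differs from compound 1 in more than one place, so no single step between the two measured compounds can be drawn, and the pair shows only that one compound is active while the other reports a limit.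

The compound now considered is compound 3, `Cc1cc(C)c2oc(N3CCN(C)CC3)nc2c1`. It arises from compound 1 by hydrogen in place of methyl on a saturated chain carbon bound to an aromatic carbon. Going by the values given here, as no measured pair mirrors this change, the step from compound 1 to compound 3 in this assay is expected to be small, with a slight loss or none beyond the usual scatter, as expressed by a number 0.26 log units lower from compound 1 to compound 3 (within the scatter). Compound 3 is therefore estimated at 6.2, with a range from 5.4 to 6.9.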

Compound 3, negative logarithm of the half-maximal effective concentration: 6.32
Beside the measured number, compound 3's estimate is 0.12 log units below it; low and high end bracket the measured number.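

Among the compounds shown here, until compound 3, the set held no step in a single place, so nothing could be said about any one position on the shared core in this assay. Shortening ethyl to methyl, on a saturated chain carbon bound to an aromatic carbon, gives a number 0.14 log units lower from compound 1 to compound 3 (within the scatter), so within this pair the agonist activity does not depend on the full ethyl chain at this place. Compound 2 stays outside this comparison, since it differs from compound 1 in more than one place and its reading is only a limit: the limit of < 4 in this assay, at which 1 of the 3 values shown sits.

What the compounds shown leave open is how far this place accepts change in either direction: a longer chain such as propyl, hydrogen in place of the whole ethyl, or a group of another kind such as an amine or a carboxylic acid could each read differently. For the compounds shown here, the single step also cannot tell whether ethyl and methyl would remain interchangeable on a core carrying other groups, and the limit of compound 2 cannot be assigned to either of the places in which it differs from compound 1.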